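The source may report more compounds than this note shows. Statements on the series, on what has been measured and on what is new or still open speak of the compounds shown alone.

Compound 1: `O=C(N/N=C/c1cccs1)c1ccc(-c2nc3ccccc3s2)cc1`, 8480 nM
Compound 2: `O=C(N/N=C/c1ccccc1O)c1ccc(-c2nc3ccccc3s2)cc1`, 5550 nM
Compound 3: `O=C(N/N=C/c1ccc(F)c(Br)c1)c1ccc(-c2nc3ccccc3s2)cc1`, 28000 nM

These three compounds share one core and differ only in the group on a carbon with a double bond to nitrogen. In an assay on isolated protein for inhibition of Maltase-glucoamylase (Homo sapiens), with a stated time of 15 min (on this read-out lower numbers stand for stronger inhibition and higher numbers for weaker inhibition), compound 3 stands at the high end of the three numbers: the step of a 3.3-fold higher number from compound 1 to compound 3 (0.52 log units; beyond the scatter) and the step of a 5.0-fold higher number from compound 2 to compound 3 (0.70 log units; beyond the scatter) both lie beyond the scatter, while compound 1 and compound 2 sit within the scatter of each other, as the step of a 1.5-fold lower number from compound 1 to compound 2 (0.18 log units; within the scatter) shows.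

Compound 4 is `O=C(N/N=C/c1cccc(O)c1)c1ccc(-c2nc3ccccc3s2)cc1`. It differs from compound 3 in one place: 3-hydroxyphenyl in place of 3-bromo-4-fluorophenyl on a carbon with a double bond to nitrogen. The step that bears most directly on this change is a 5.0-fold higher number from compound 2 to compound 3 (0.70 log units; beyond the scatter), since it ran from a hydroxyphenyl group to the 3-bromo-4-fluorophenyl group and is here roughly reversed; the step of a 3.3-fold higher number from compound 1 to compound 3 (0.52 log units; beyond the scatter) points the same way. A modest lower number is therefore expected in this assay, roughly undoing the rise seen for compound 3. Compound 4 is estimated at 6500 nM, with a range from 2500 nM to 17000 nM, which means an expected step of a 4.3-fold lower number from compound 3 to compound 4 (0.63 log units; beyond the scatter).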

Compound 4, half-maximal inhibitory concentration: 9210 nM
Compound 4: middle estimate off by 1.4-fold (0.15 log units), on the low side, within the range that was stated.
By their numbers in this assay, from the lowest: compounds 2, 1 and 4 (each within the scatter of the next); then compound 3.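

In this assay, the 3-hydroxyphenyl group cannot be told apart from either the 2-hydroxyphenyl or the thiophen-2-yl group: a 1.7-fold higher number from compound 2 to compound 4 (0.22 log units; within the scatter) and a 1.1-fold higher number from compound 1 to compound 4 (0.04 log units; within the scatter) both stay within the scatter, so among these compounds the two hydroxyphenyl groups give no measurable difference. The step of a 3.0-fold lower number from compound 3 to compound 4 (0.48 log units; beyond the scatter) lies beyond the scatter, which leaves compound 3 as the weakest of the four, its steps to each of the others now all being beyond the scatter. No supporting measurement is available to explain these differences.

From the compounds shown here alone, it remains open whether the bromine or the fluorine alone, as in a 3-bromophenyl or a 4-fluorophenyl group, would give a number like that of compound 3. Going by these compounds, how an amine or a carboxylic acid on the phenyl ring in place of the hydroxyl would read also remains open.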